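This account rests on a few compounds, and the source may have more. Where it says the series, first, only, none or still open, it means among the compounds named here.

Working notes on the series in a functional assay on HepG2 cells (Homo sapiens) for cytotoxicity, read by MTT assay, with a stated time of 24 h; on this read-out lower numbers stand for stronger inhibition and higher numbers for weaker inhibition. Of the compounds shown here, two have numbers so far. Compound 1 `COc1cc(/C=C2\CN(C)C/C(=C\c3ccc(Cl)c(Cl)c3)C2=O)cc(OC)c1OC` gives 6960 nM, and compound 2 `CN1C/C(=C\c2ccc(Br)cc2)C(=O)/C(=C/c2cccc([N+](=O)[O-])c2)C1` gives 8800 nM. These two values lie within the usual scatter of each other, so compound 2 stands level with compound 1 on the numbers shown, and no order can be read between them.

Next in line is compound 3 `CN1C/C(=C\c2cccc(Br)c2)C(=O)/C(=C/c2cccc([N+](=O)[O-])c2)C1`, not yet measured. It differs from compound 2 by having 3-bromophenyl in place of 4-bromophenyl on a double-bonded chain carbon bound to a double-bonded ring carbon. The two have the same atoms, joined differently. Within the data shown here, the series holds no measured step between compounds that differ in one place, so the value of compound 2, 8800 nM, is the main anchor. No shift beyond the scatter is expected in this assay, and neither direction is favoured. The expected change is a 1.1-fold lower number from compound 2 to compound 3 (0.04 log units; within the scatter). For compound 3 the estimate is 8000 nM, with an expected range of 3500 nM to 18000 nM.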

Compound 3, half-maximal inhibitory concentration: 4890 nM
Compound 3: middle estimate off by 1.6-fold (0.21 log units), on the high side, within the range that was stated.
By their numbers in this assay, from the lowest: compounds 3, 1 and 2 (each within the scatter of the next).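

In this assay, among these compounds, 3-bromophenyl in place of 4-bromophenyl on a double-bonded chain carbon bound to a double-bonded ring carbon gives a 1.8-fold lower number from compound 2 to compound 3 (0.26 log units; within the scatter), the first step between compounds that differ in one place. This step stays within the usual scatter, so the two bromophenyl isomers cannot be told apart at this place on this read-out, and compound 2 and compound 3 stand level. Nothing measured here bears on the reason for this result.

Still open, as far as these compounds go, is whether a group of another kind at this place, such as an unsubstituted phenyl, a pyridine ring or an aminophenyl, would move the number beyond the scatter. Also open, from the compounds shown here alone, is whether the two bromophenyl isomers would still stand level if an amine or a nitrile took the place of the nitro group that compound 2 and compound 3 share.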